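From Pyridin-2-yl to Thiophen-3-yl on the Shared Core

The source may report more compounds than this note shows. Statements on the series, on what has been measured and on what is new or still open speak of the compounds shown alone.

Compound 1, `CCc1nc2c(OCc3ccccc3)cccn2c1N`, gives 83% in a functional assay on the whole organism with Rattus norvegicus as the target, at a dose of 40 mg/kg by the intraperitoneal route; on this read-out lower numbers stand for less inhibition and higher numbers for more inhibition at the one dose given (going by the name of the read-out).
Compound 2, `Cc1nc2c(OCc3ccccc3F)cccn2c1N`, gives 93% in this assay.
Compound 3, `Cc1nc2c(OCc3ccccn3)cccn2c1N`, gives 16% in this assay.

Compound 3 stands lowest of the three numbers; compound 1 lies nearest, beyond the usual scatter, and compound 2 lies furthest, also beyond it. Compound 4, `Cc1nc2c(OCc3ccsc3)cccn2c1N`, has not yet been measured. It differs from compound 3 in one place: thiophen-3-yl in place of pyridin-2-yl on a saturated chain carbon bound to an oxygen on an aromatic ring. Within the data shown here, no pair of measured compounds shows this kind of change, so the size of the step cannot be read off directly. Because compound 3 gives 16% while compound 1 gives 83%, the step from compound 3 to compound 4 is expected to be upward and well beyond the scatter, a number 44 percentage points higher from compound 3 to compound 4 (beyond the scatter). For compound 4 the estimate is 60%, expected to fall between 25% and 90%.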

Compound 4, a percentage reported as inhibition, in the whole organism at one dose (the size of the read-out at that dose, not a potency): 52%
The estimate for compound 4 lay 8 percentage points above the measured number; measured number inside the range.
By their numbers in this assay, from the lowest: compound 3; then compound 4; then compounds 1 and 2 (each within the scatter of the next).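

In this assay, the group on a saturated chain carbon bound to an oxygen on an aromatic ring clearly matters: thiophen-3-yl in place of pyridin-2-yl gives a number 36 percentage points higher from compound 3 to compound 4 (beyond the scatter) on the shared core. This change swaps a six-membered aromatic ring containing nitrogen for a five-membered one containing sulfur, so ring size and hetero atom change together. No measurement here explains the rise.

Which of those two differences carries the step stays open. Furan-3-yl, a five-membered ring with oxygen, could help separate them.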